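Swapping the Diamine Chain for a Piperidinylpropyl Group

The source may hold more compounds than are shown below. What is called first, only, known or untested is meant among the compounds shown, and "the series" means these compounds.

Compound 1, `CCCCCCCCCCc1ccc(-c2noc([C@H]3CCCN3)n2)cc1`, gives 12% in an assay on HeLa cells for inhibition of sphingosine-1-phosphate transporter SPNS2 (Mus musculus), read by LC-MS, tested at 2 uM; on this read-out higher numbers stand for more inhibition at the one concentration tested (going by the name of the read-out) and lower numbers for less inhibition.
Compound 2, `CCCCCCCCCCc1ccc(-c2noc([C@@H]3CC[C@H](N)C3)n2)cc1`, gives 38% in this assay.
Compound 3, `CCCCCCCCCCc1ccc(-c2noc([C@@H](N)CCCCN)n2)cc1`, gives 43% in this assay.

Compound 3 shows the highest of the three numbers; compound 2 sits close, within the scatter, while compound 1 lies well below. Compound 4, `CCCCCCCCCCc1ccc(-c2noc(CCCN3CCCCC3)n2)cc1`, differs from compound 3 at one place: 3-(piperidin-1-yl)propyl in place of 1,5-diaminopentyl on an aromatic carbon. Among the compounds with values here, two measured steps touch the same position: a number 31 percentage points higher from compound 1 to compound 3 (beyond the scatter) and a number 5 percentage points higher from compound 2 to compound 3 (within the scatter). Both ended at compound 3, so they show that this position matters but not what a group with no hydrogen-bond donor will do. A step somewhat downward, of uncertain size, is expected: a number 13 percentage points lower from compound 3 to compound 4 (beyond the scatter). Compound 4 is therefore estimated at 30%, with a range from 8% to 55%.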

Compound 4, a percentage reported as inhibition, at one concentration (the size of the read-out at that concentration, not a potency): 0%
Estimate against measurement, compound 4: 30 percentage points above, and the stated range ends above it.
By their numbers in this assay, from the lowest: compound 4; then compound 1; then compounds 2 and 3 (each within the scatter of the next).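

With 3-(piperidin-1-yl)propyl at this position in this assay, the steps are a number 43 percentage points lower from compound 3 to compound 4 (beyond the scatter), a number 38 percentage points lower from compound 2 to compound 4 (beyond the scatter) and a number 12 percentage points lower from compound 1 to compound 4 (beyond the scatter), so this group ranks below even the pyrrolidin-2-yl group. The change removes both hydrogen-bond donors of 1,5-diaminopentyl and adds a six-membered ring in one move, so the effects of the two cannot be separated. No measurement on hand explains the drop.

Still open, from the compounds shown here alone, is whether a 3-aminopropyl group, a primary amine on the same propyl chain, would restore the number.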